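The source may report more compounds than this note shows. Statements on the series, on what has been measured and on what is new or still open speak of the compounds shown alone.

Measured so far in a functional assay on the whole organism (blood, strain Wistar-Okamoto) with Rattus norvegicus as the target, with a stated time of 5 days; on this read-out higher numbers stand for an effect only at larger amounts of compound and lower numbers for an effect already at smaller amounts:
compound 1, `C/N=C(\NC#N)Nc1cccnc1`: > 50 mg/kg, a limit of the assay rather than a number
compound 2, `CCC(C)/N=C(\NC#N)Nc1cccnc1`: 20 mg/kg
compound 3, `CCCC(C)(C)/N=C(\NC#N)Nc1cccnc1`: 1 mg/kg

Compound 3 holds the lowest of the numbers read in this assay; the nearest is a 20-fold lower number from compound 2 to compound 3 (1.30 log units; beyond the scatter). The value of compound 1 is the limit of > 50 mg/kg in this assay, at which 1 of the 3 values shown sits. Both steps away from compound 1 ran the same way: an at least 2.5-fold lower number from compound 1 to compound 2 (0.39 log units; beyond the scatter) and an at least 50-fold lower number from compound 1 to compound 3 (1.69 log units; beyond the scatter). Across these three compounds, every enlargement of the group on the double-bonded nitrogen has brought a lower minimum effective dose, and no compound goes against that.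

Compound 4, `CC(C)(C)CC(C)(C)/N=C(\NC#N)Nc1cccnc1`, is not yet measured. Its change from compound 3 is tert-butyl in place of ethyl on a saturated chain carbon, two bonds along the chain from a double-bonded nitrogen. Within the data shown here, the group on the double-bonded nitrogen grows once more, and the only measured steps that bear on such growth are the two above, both beyond the scatter and both downward. Those steps altered the group on the double-bonded nitrogen itself, whereas this change sits two bonds along the chain from a double-bonded nitrogen, so a smaller lowering is expected: the estimated step is a 2.0-fold lower number from compound 3 to compound 4 (0.30 log units; within the scatter). Compound 4 is therefore expected at 0.5 mg/kg, with a range from 0.15 mg/kg to 2 mg/kg.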

Compound 4, minimum effective dose: 50 mg/kg
For compound 4 the middle estimate is 100-fold (2.00 log units) below the measured one; measured number above the stated range.
By their numbers in this assay, from the lowest: compound 3; then compound 2; then compound 4.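

In this assay, enlargement of the group on the double-bonded nitrogen no longer runs one way: tert-butyl in place of ethyl on a saturated chain carbon, two bonds along the chain from a double-bonded nitrogen, gives a 50-fold higher number from compound 3 to compound 4 (1.70 log units; beyond the scatter), so compound 4 goes against the downward run of compound 1, compound 2 and compound 3. The earlier steps shown here altered the group on the double-bonded nitrogen itself, and this one shows that a change further out along the chain can move the number as strongly, since it is as large as a 20-fold lower number from compound 2 to compound 3 (1.30 log units; beyond the scatter) but runs the opposite way. Compound 1 stays outside any order by number, since its value is a limit and not a number: the limit of > 50 mg/kg in this assay, at which 1 of the 4 values shown sits.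

As far as these compounds go, whether the rise belongs to tert-butyl as such or to any growth at this place stays open; isopropyl or a longer unbranched chain such as butyl on the same carbon would separate the two. How a hydroxyl or an amine would read at this place is equally open, and nothing shown gives a reason for the reversal.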